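Series notes: trifluoromethoxy in place of tert-butyl

This account rests on a few compounds, and the source may have more. Where it says the series, first, only, none or still open, it means among the compounds named here.

Values so far in an ADME assay on MDBK cells (Bos taurus) for cytotoxicity; a lower number here means that less compound is tolerated, a higher number that more compound is tolerated
- Compound 1 `Fc1ccc(Cn2ccc3nc(-c4ccccc4)nc-3c2)cc1` gives > 100000 nM as a limit
- Compound 2 `Clc1ccc(Cn2ccc3nc(-c4ccccc4)nc-3c2)cc1` gives > 100000 nM as a limit
- Compound 3 `CC(C)(C)c1ccc(Cn2ccc3nc(-c4ccccc4)nc-3c2)cc1` gives 22000 nM as a number

Among the compounds with values here, compound 3 holds the only actual number here, and the other two values are limits. Compound 4 `FC(F)(F)Oc1ccc(Cn2ccc3nc(-c4ccccc4)nc-3c2)cc1` carries trifluoromethoxy in place of tert-butyl on an aromatic carbon, para to a large group (trifluoromethoxy in place of tert-butyl on an aromatic carbon). Within the data shown here, two measured steps bear on this change. Each of an at least 4.5-fold lower number from compound 1 to compound 3 (0.65 log units; beyond the scatter) and an at least 4.5-fold lower number from compound 2 to compound 3 (0.65 log units; beyond the scatter) brought in tert-butyl, so removing it is expected to recover part of that drop in this assay as a modest rise. Trifluoromethoxy itself is still unmeasured, so the estimated step is a 2.0-fold higher number from compound 3 to compound 4 (0.31 log units; beyond the scatter) and no more than that is assumed. Compound 4 is expected at 45000 nM with an estimated range from 18000 nM to 100000 nM as the working figure.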

Compound 4, half-maximal cytotoxic concentration: 66000 nM
Estimate against measurement, compound 4: 1.5-fold (0.17 log units) below; low and high end bracket the measured number.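

In this assay, trifluoromethoxy in place of tert-butyl gives a 3.0-fold higher number from compound 3 to compound 4 (0.48 log units; beyond the scatter), so the drop seen with tert-butyl does not carry over to every group beyond fluoro and chloro at this position. Against the chloro and fluoro compounds only floors can be read, an at least 1.5-fold lower number from compound 2 to compound 4 (0.18 log units; that floor lies within the scatter) and an at least 1.5-fold lower number from compound 1 to compound 4 (0.18 log units; that floor lies within the scatter), so any real drop from those two remains unsettled, the floors being set by the assay limit: the limit of > 100000 nM in this assay, at which 2 of the 4 values shown sit.

Going by these compounds, what an amine, a carboxylic acid or a longer chain would give at this position stays open.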